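The source may report more compounds than this note shows. Statements on the series, on what has been measured and on what is new or still open speak of the compounds shown alone.

Compound 1 `Nc1cc(N)c2nc(-c3ccccc3)c(NCc3ccc(Cl)c(Cl)c3)nc2c1` gives < 100000 nM in a functional assay on HCT-15 cells (Homo sapiens) for inhibition, read by sulforhodamine B assay, with a stated time of 48 h (on this read-out lower numbers stand for higher toxicity in this test and higher numbers for lower toxicity in this test), a limit of the assay rather than a number.
Compound 2 `COc1ccc(CNc2nc3cc(N)cc(N)c3nc2-c2ccccc2)cc1OC` gives < 100000 nM in this assay, again a limit.
Compound 3 `Nc1cc(N)c2nc(-c3ccccc3)c(NCc3ccc(F)cc3)nc2c1` gives < 100000 nM in this assay, likewise a limit.

Compound 3 therefore stands at the same limit as the other two measured compounds, and none of the three values is a number that can be ranked. The step from compound 1 to compound 2 a step that the two limits leave unreadable from compound 1 to compound 2, the step from compound 1 to compound 3 a step that the two limits leave unreadable from compound 1 to compound 3 and the step from compound 2 to compound 3 a step that the two limits leave unreadable from compound 2 to compound 3 are all left unreadable by the limits, as noted in the limit of < 100000 nM in this assay, at which 3 of the 3 values shown sit.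

Compound 4 `COc1ccc(CNc2nc3cc(N)cc(N)c3nc2-c2ccccc2)cc1` differs from compound 3 by methoxy in place of fluoro on an aromatic carbon. All three measured steps concern exchanges of the substituted phenyl group on the benzylic nitrogen, so they bear on this change, but none of them has a readable size. The expected step from compound 3 to compound 4 is a step that the limit leaves unreadable from compound 3 to compound 4, carrying no direction that the data can support. Compound 4 is estimated at 20000 nM in this assay, with a range from 3000 nM to 90000 nM.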

Compound 4, concentration lethal to 50% of the cells: 75900 nM
For compound 4 the middle estimate is 3.8-fold (0.58 log units) below the measured one, and the stated range covers the measured number.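

For the compounds shown here, compound 4 has a measured number, but no step to it from compound 1, compound 2 or compound 3 can be read, because those three compounds give only a limit: the limit of < 100000 nM in this assay, at which 3 of the 4 values shown sit. The compounds shown leave open how much the exchanges on the phenyl group change the read-out in this assay.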